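The compounds below may be only part of what the source reports. "The series", "measured", "known", "first", "only" and "open" are said of these compounds alone.

Compound 1, `CS(=O)(=O)CCCn1c(Cn2c(=O)n(C3CC3)c3ccncc32)cc2cc(Cl)ccc21`, in an ADME assay on HeLa cells (Homo sapiens) for cytotoxicity, read by ATP content, with a stated time of 3 days (on this read-out higher numbers stand for lower toxicity in this test and lower numbers for higher toxicity in this test), gives > 50000 nM, which is a limit of the test and not a number.
Compound 2, `O=c1n(Cc2cc3cc(Br)ccc3n2CCCCO)c2cnccc2n1C1CC1`, in this assay gives > 50000 nM, again a limit.
Compound 3, `CS(=O)(=O)CCCn1c(Cn2c(=O)n(C3CC3)c3ccncc32)cc2cc(C(F)(F)F)ccc21`, in this assay gives > 50000 nM, also a limit.

Compound 3 thus stands where every compound shown stands: at the edge of what this assay can report, with no number that would set it apart from compound 1 or compound 2. Within the data shown here, the single measured step that touches a change on the same aromatic carbon, a step that the two limits leave unreadable from compound 1 to compound 3, cannot be read in size, because of the limit of > 50000 nM in this assay, at which 3 of the 3 values shown sit.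

Compound 4, `CS(=O)(=O)CCCn1c(Cn2c(=O)n(C3CC3)c3ccncc32)cc2cc(Br)ccc21`, differs from compound 3 by bromo in place of trifluoromethyl on an aromatic carbon. Among the measured compounds shown here, the only measured step that bears on this change is the one just described, and it gives no readable size, so it offers no ground to expect a shift in this assay beyond the usual scatter. The expectation is instead that compound 4 will behave like the three compounds already measured and sit at the same limit. The step from compound 3 to compound 4 is therefore estimated as a step that the limit leaves unreadable from compound 3 to compound 4. For compound 4 the estimated value in this assay is 80000 nM, within a range from 30000 nM to 300000 nM.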

Compound 4, half-maximal cytotoxic concentration: > 50000 nM
Compound 4 ended at the assay's limit; the forecaster's own chance of this, stated with the estimate: 85%; the middle value does not contradict the limit.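

No step from compound 1, compound 2 or compound 3 to compound 4 can be read in size, because each of the two values in every pair is a limit and not a number: the limit of > 50000 nM in this assay, at which 4 of the 4 values shown sit.

The compounds shown leave open how far apart they truly lie in this assay, and whether any change to the shared core would give a readable value.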